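The source may report more compounds than this note shows. Statements on the series, on what has been measured and on what is new or still open speak of the compounds shown alone.

Compound 2, `O=C1c2sccc2N(Cc2ccccc2Br)S(=O)(=O)N1Cc1ccccc1`, was tested in an ADME assay on MT4 cells (Homo sapiens) for cytotoxicity, read by MTT assay, with a stated time of 4 days; on this read-out lower numbers stand for higher toxicity in this test and higher numbers for lower toxicity in this test. In this assay compound 2 gives only a limit of the assay, > 270000 nM. Its closest measured neighbour is compound 1, `O=C1c2sccc2N(Cc2ccccc2Cl)S(=O)(=O)N1Cc1ccccc1`, which differs by chloro in place of bromo on an aromatic carbon. In this assay compound 1 likewise gives only a limit of the assay, > 298000 nM. The step that the two limits leave unreadable from compound 1 to compound 2 cannot be sized because both values are limits, the limit of > 298000 nM in this assay, at which 1 of the 2 values shown sits, and (the limit of > 270000 nM in this assay, at which 1 of the 2 values shown sits).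

Compound 3, `O=C1c2sccc2N(Cc2ccc(Cl)cc2)S(=O)(=O)N1Cc1ccccc1`, carries 4-chlorophenyl in place of 2-bromophenyl on a saturated chain carbon bound to a sulfonamide nitrogen in a ring. Among the measured compounds shown here, the only measured step that bears on this change is unreadable, and both known compounds sit at the upper edge of what this assay can measure, so no shift beyond the scatter is expected. Compound 3 is therefore expected to give about 300000 nM, within 150000 nM to 600000 nM. The expected step is a step that the limit leaves unreadable from compound 2 to compound 3, and a further limit rather than a number is the likely outcome.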

Compound 3, half-maximal cytotoxic concentration: 8200 nM
For compound 3 the middle estimate is 37-fold (1.56 log units) above the measured one; measured number outside the range, below it.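

Compound 1 and compound 2 gave only limits of the assay, so the step between them could not be read and this position looked silent in this assay. Putting 4-chlorophenyl in place of 2-chlorophenyl on the saturated chain carbon gives an at least 36-fold lower number from compound 1 to compound 3 (1.56 log units; beyond the scatter), so with chlorine kept, the change of phenyl group alone brings the read-out into the measurable range, towards higher toxicity in this test. Putting 4-chlorophenyl in place of 2-bromophenyl gives an at least 32-fold lower number from compound 2 to compound 3 (1.51 log units; beyond the scatter), and both steps are minimum sizes, each starting from a limit of the assay.

No measurement here bears on what lies behind this shift. Going by these compounds, whether 4-bromophenyl or 4-methoxyphenyl at this place would give a number as low as that of compound 3 remains open.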